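Naphthyl in Place of Iodophenyl on a Dimethoxybenzyl Core

This account rests on a few compounds, and the source may have more. Where it says the series, first, only, none or still open, it means among the compounds named here.

Compound 1 `CCCCCCOc1cc(NC(=O)c2ccc(I)cc2)ccc1N(C)S(C)(=O)=O` and compound 2 `CCCCCCOc1cc(NC(=O)c2ccc3ccccc3c2)ccc1N(C)S(C)(=O)=O` share a core and differ by naphthalen-2-yl in place of 4-iodophenyl on a carbonyl carbon. In a functional assay on SK-BR-3 cells (Homo sapiens) for antiproliferative activity, read by MTT assay, with a stated time of 48 h (a lower number here means a stronger inhibitor, a higher number a weaker inhibitor), compound 1 gives 12700 nM, while compound 2 gives 64300 nM; the step is a 5.1-fold higher number from compound 1 to compound 2 (0.70 log units; beyond the scatter). Compound 3 `COc1ccc(OC)c(COc2cc(NC(=O)c3ccc(I)cc3)ccc2N(C)S(C)(=O)=O)c1` differs from compound 1 by 2,5-dimethoxyphenyl in place of pentyl on a saturated chain carbon bound to an oxygen on an aromatic ring, and in this assay compound 3 gives 1.21 nM, which amounts to a 10000-fold lower number from compound 1 to compound 3 (4.02 log units; beyond the scatter). Compound 4 `COc1ccc(OC)c(COc2cc(NC(=O)c3ccc4ccccc4c3)ccc2N(C)S(C)(=O)=O)c1` is not yet measured; it differs from compound 3 by naphthalen-2-yl in place of 4-iodophenyl on a carbonyl carbon, the same change that turns compound 1 into compound 2, now made on the core of compound 3. The earlier step read a 5.1-fold higher number from compound 1 to compound 2 (0.70 log units; beyond the scatter). As far as these compounds go, on that basis a step of similar size is expected for compound 4, a 5.0-fold higher number from compound 3 to compound 4 (0.70 log units; beyond the scatter), though whether it carries over to this core is untested. Compound 4 is accordingly estimated at 6 nM, between 1.5 nM and 40 nM.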

Compound 4, half-maximal inhibitory concentration: 16.6 nM
Estimate against measurement, compound 4: 2.8-fold (0.44 log units) below; the range from low to high includes it.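

In this assay, the change to naphthalen-2-yl reads a 14-fold higher number from compound 3 to compound 4 (1.14 log units; beyond the scatter), so the direction seen on the core of compound 1 carries over, but the size does not: the same change on two cores in this assay, a 5.1-fold higher number (0.70 log units; beyond the scatter) from compound 1 to compound 2 and a 14-fold higher number (1.14 log units; beyond the scatter) from compound 3 to compound 4, 2.7-fold (0.43 log units) apart, beyond the scatter of two such steps. Read the other way, 2,5-dimethoxyphenyl in place of pentyl remains a large step when naphthalen-2-yl is present, at a 3900-fold lower number from compound 2 to compound 4 (3.59 log units; beyond the scatter), yet its size also depends on the partner group: the same change on two cores in this assay, a 10000-fold lower number (4.02 log units; beyond the scatter) from compound 1 to compound 3 and a 3900-fold lower number (3.59 log units; beyond the scatter) from compound 2 to compound 4, 2.7-fold (0.43 log units) apart, beyond the scatter of two such steps. These four compounds show that the two changes do not add up exactly, but they do not show why, or how either change would behave on any further core.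

As far as these compounds go, it remains open whether the same direction would hold for a phenyl ring bearing an amine or a carboxylic acid on the carbonyl carbon. From the compounds shown here alone, it is also open how a longer chain in place of pentyl would read.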